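Ethoxycarbonyl in place of 1-hydroxyethyl: working notes

The compounds below may be only part of what the source reports. "The series", "measured", "known", "first", "only" and "open" are said of these compounds alone.

Measured in a functional assay on cells (Homo sapiens), read by thymidine incorporation; a lower number here means a stronger inhibitor, a higher number a weaker inhibitor:
- compound 1 `CCc1cc(NCc2cccnc2)n2ncc(Br)c2n1`: 520 nM
- compound 2 `Brc1cnn2c(NCc3cccnc3)cc(C3CC3)nc12`: 1500 nM
- compound 3 `CC(O)c1cc(NCc2cccnc2)n2ncc(Br)c2n1`: 1400 nM

Compound 3 at 1400 nM is level with compound 2, as a 1.1-fold lower number from compound 2 to compound 3 (0.03 log units; within the scatter) shows, and stands apart from compound 1, with a 2.7-fold higher number from compound 1 to compound 3 (0.43 log units; beyond the scatter). Compound 4 `CCOC(=O)c1cc(NCc2cccnc2)n2ncc(Br)c2n1` places ethoxycarbonyl on the same aromatic carbon in place of 1-hydroxyethyl: ethoxycarbonyl in place of 1-hydroxyethyl on an aromatic carbon. All measured steps fall on this carbon: besides those two, there is a 2.9-fold higher number from compound 1 to compound 2 (0.46 log units; beyond the scatter). These steps are modest or within the scatter, and none involves an ester, so no firm direction follows. In this assay, a modest step at most is expected, possibly none beyond the scatter. The expected step is a 1.2-fold lower number from compound 3 to compound 4 (0.07 log units; within the scatter). Compound 4 is estimated at 1200 nM, with an expected range of 400 nM to 3500 nM.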

Compound 4, half-maximal inhibitory concentration: 2900 nM
Beside the measured number, compound 4's estimate is 2.4-fold (0.38 log units) below it; the range from low to high includes it.
By their numbers in this assay, from the lowest: compound 1; then compounds 3, 2 and 4 (each within the scatter of the next, the first and the last beyond it).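

In this assay the ester gives a 2.1-fold higher number from compound 3 to compound 4 (0.32 log units; beyond the scatter) and so sits weaker at this aromatic carbon than the 1-hydroxyethyl compound. Against cyclopropyl there is a 1.9-fold higher number from compound 2 to compound 4 (0.29 log units; within the scatter) and no separation, while against ethyl there is a 5.6-fold higher number from compound 1 to compound 4 (0.75 log units; beyond the scatter) and the largest gap in the series, which leaves compound 1 the strongest of the four. Nothing available bears on the cause of these steps.

Still open, from the compounds shown here alone, is whether a carboxylic acid, a primary amide or a longer alkyl chain such as propyl on this carbon would reach or pass ethyl.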